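Chloro added to compound 3: expected effect

This account rests on a few compounds, and the source may have more. Where it says the series, first, only, none or still open, it means among the compounds named here.

Measured in an ADME assay on HCT-116 cells (Homo sapiens) for antiproliferative activity (on this read-out higher numbers stand for weaker inhibition and lower numbers for stronger inhibition), so far
Compound 1 `COc1ccc(C(N)=O)cc1/C=C/c1ccc(Cl)cc1` gives 7100 nM
Compound 2 `COc1ccc(C(N)=O)cc1/C=C/c1ccccc1` gives 36000 nM
Compound 3 `COc1ccc(C(N)=O)cc1/C=C/c1ccccc1Cl` gives > 50000 nM as a limit

Compound 3 stands at the limit of > 50000 nM in this assay, at which 1 of the 3 values shown sits, and so has a limit and not a number. Compound 4 `COc1ccc(C(N)=O)cc1/C=C/c1ccc(Cl)cc1Cl` differs from compound 3 by chloro in place of hydrogen on an aromatic carbon and the entering chloro sits meta to a chloro group and para to a large group.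

Among the measured compounds shown here, two measured steps bear on this change. The more useful one is a 5.1-fold higher number from compound 1 to compound 2 (0.71 log units; beyond the scatter) and it is modest but beyond the scatter. Read in reverse, it has chloro in place of hydrogen giving the lower number, with compound 1 carrying the chloro. The other is an at least 1.3-fold higher number from compound 2 to compound 3 (0.14 log units; that floor lies within the scatter) and its floor lies within the scatter, so it sets no size for the present change.

A modest move to a lower number is therefore expected, of about the size seen between compound 1 and compound 2. The starting point is only a limit, so the expected size stays loose. The estimate is an at least 4.1-fold lower number from compound 3 to compound 4 (0.61 log units; beyond the scatter) in this assay and it could prove larger. Compound 4 is expected at 12000 nM (estimated range 4000 nM to 40000 nM).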

Compound 4, half-maximal inhibitory concentration: > 50000 nM
Compound 4 ended at the assay's limit; the forecaster's own chance of this, stated with the estimate: 15%; middle value at least 4.1-fold (0.61 log units) away from the limit.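

In this assay compound 4 joins compound 3 at the assay's limit, which is a limit and not a number, so the step between them cannot be read, and the lower number that chloro para to a large group gave in compound 1 against compound 2 does not appear as a measurable value here: the limit of > 50000 nM in this assay, at which 2 of the 4 values shown sit.

Among the compounds shown here, the one readable step places a further chloro on compound 1 and gives an at least 7.0-fold higher number from compound 1 to compound 4 (0.84 log units; beyond the scatter), so the activity of compound 1 does not survive this second chloro, and on this core the chloro meta to a chloro group goes with a loss and not a gain.

The further chloro has now been seen on two cores, with only the second step clearly beyond the scatter: the same change on two cores in this assay, an at least 1.3-fold higher number (0.14 log units; that floor lies within the scatter) from compound 2 to compound 3 and an at least 7.0-fold higher number (0.84 log units; beyond the scatter) from compound 1 to compound 4; the limit leaves it open whether they differ.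

As far as these compounds go, how far compound 3 and compound 4 lie past the limit stays open, and with it whether chloro at this position has any effect at all once the other chloro is present. Also open, from the compounds shown here alone, is whether a different group at this position, such as fluoro or an amine, would follow chloro in compound 1 or fall to the limit.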